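Pyridin-3-yl in place of pyridin-2-yl on the amide nitrogen

The source may report more compounds than this note shows. Statements on the series, on what has been measured and on what is new or still open speak of the compounds shown alone.

Compound 3 `COc1cc2c(cc1OC)C(CC(=O)Nc1ccccn1)CC2` stands second highest of the three compounds measured in a functional assay on the whole organism (strain Wistar) for inhibition, with Rattus norvegicus as the target, read by paw edema, with a stated time of 3 h, at a dose of 100 mg/kg (on this read-out lower numbers stand for less inhibition and higher numbers for more inhibition at the one dose given (going by the name of the read-out)), where compound 3 gives 30.4%. Compound 1 `COc1cc2c(cc1OC)C(CC(=O)Nc1ccccc1)CC2` gives 36.2%, and compound 2 `COc1ccccc1NC(=O)CC1CCc2cc(OC)c(OC)cc21` gives 21.7%. The change to compound 4 `COc1cc2c(cc1OC)C(CC(=O)Nc1cccnc1)CC2` is pyridin-3-yl in place of pyridin-2-yl on an amide-type nitrogen. Two measured steps also alter the group on the amide-type nitrogen: a number 5.8 percentage points lower from compound 1 to compound 3 (within the scatter) and a number 8.7 percentage points higher from compound 2 to compound 3 (within the scatter). Only a number 14.5 percentage points lower from compound 1 to compound 2 (beyond the scatter) went beyond the scatter, and that step concerns a methoxy group, not the ring bearing the nitrogen. For the measured compounds named here, no measured pair exchanges pyridin-2-yl for pyridin-3-yl. For compound 4 a step of a number 0.4 percentage points lower from compound 3 to compound 4 (within the scatter) is expected in this assay, nothing beyond the scatter in either direction. Compound 4 is therefore estimated at 30%, between 18% and 42%.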

Compound 4, a percentage reported as inhibition, in the whole organism at one dose (the size of the read-out at that dose, not a potency): 33.3%
Beside the measured number, compound 4's estimate is 3.3 percentage points below it, and the stated range covers the measured number.
By their numbers in this assay, from the lowest: compounds 2, 3, 4 and 1 (each within the scatter of the next, the first and the last beyond it).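

In this assay, pyridin-3-yl in place of pyridin-2-yl on the amide-type nitrogen gives a number 2.9 percentage points higher from compound 3 to compound 4 (within the scatter), so this exchange does not separate the two compounds. Pyridin-3-yl in place of phenyl gives a number 2.9 percentage points lower from compound 1 to compound 4 (within the scatter), while pyridin-3-yl in place of 2-methoxyphenyl gives a number 11.6 percentage points higher from compound 2 to compound 4 (beyond the scatter), a step that, unlike the one from compound 2 to compound 3, goes beyond the scatter. No evidence is at hand that would account for these numbers. The compounds shown leave open how pyridin-4-yl, or a phenyl carrying a carboxylic acid, would read on this nitrogen.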